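Moving the Fluoro Group on the Aromatic Nitrogen Substituent

The source may report more compounds than this note shows. Statements on the series, on what has been measured and on what is new or still open speak of the compounds shown alone.

Compound 1 `Cc1ccccc1-n1cc(-c2ccc(/C=C3\C(=O)Nc4ccccc43)cc2)nn1`: 9770 nM
Compound 2 `Cc1cccc(-n2cc(-c3ccc(/C=C4\C(=O)Nc5ccccc54)cc3)nn2)c1`: 4690 nM
Compound 3 `O=C1Nc2ccccc2/C1=C/c1ccc(-c2cn(-c3ccccc3F)nn2)cc1`: 12500 nM

All three compounds were tested in a functional assay on MKN-45 cells (Homo sapiens) for inhibition, read by CCK-8 assay, with a stated time of 24 h; a lower number here means a stronger inhibitor, a higher number a weaker inhibitor. Compound 3 cannot be told apart from compound 1, as a 1.3-fold higher number from compound 1 to compound 3 (0.11 log units; within the scatter) shows. It is a weaker inhibitor than compound 2, with a 2.7-fold higher number from compound 2 to compound 3 (0.43 log units; beyond the scatter).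

Compound 4 `O=C1Nc2ccccc2/C1=C/c1ccc(-c2cn(-c3ccc(F)cc3)nn2)cc1` is the next to be measured. It carries 4-fluorophenyl in place of 2-fluorophenyl on an aromatic nitrogen.

Among the measured compounds shown here, no measured pair shows the fluoro group in two different places, so the nearest guide is an analogy. In a 2.1-fold lower number from compound 1 to compound 2 (0.32 log units; beyond the scatter), 3-methylphenyl replaces 2-methylphenyl, so a methyl group changes place on the phenyl ring and the step is modest. Exchanging methyl for fluoro made no clear difference in a 1.3-fold higher number from compound 1 to compound 3 (0.11 log units; within the scatter), which gives some support for carrying that trend over to the fluoro series.

A similar or smaller move towards a lower number is therefore expected in this assay, and it may stay within the scatter. The expected change is an estimated 1.6-fold lower number from compound 3 to compound 4 (0.19 log units; within the scatter).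

The estimate for compound 4 is 8000 nM, with an expected range of 3500 nM to 16000 nM.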

Compound 4, half-maximal inhibitory concentration: 16700 nM
Compound 4: middle estimate off by 2.1-fold (0.32 log units), on the low side; measured number outside the range, above it.
By their numbers in this assay, from the lowest: compound 2; then compounds 1, 3 and 4 (each within the scatter of the next).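

In this assay, among the compounds shown here, the fluoro group can stand in either printed place on the phenyl ring without a readable change, with a 1.3-fold higher number from compound 3 to compound 4 (0.13 log units; within the scatter) as the step from 2-fluorophenyl to 4-fluorophenyl, so the modest move seen in the methyl pair, a 2.1-fold lower number from compound 1 to compound 2 (0.32 log units; beyond the scatter) as its step, has no counterpart in these two fluoro compounds. Compound 4 also cannot be told apart from the 2-methylphenyl compound, with a 1.7-fold higher number from compound 1 to compound 4 (0.23 log units; within the scatter) as the step, while it stays clearly weaker than compound 2, with a 3.6-fold higher number from compound 2 to compound 4 (0.55 log units; beyond the scatter) as the step, which leaves compound 2 as the strongest inhibitor of the four and the only one separated from the others. No measurement offered alongside these compounds accounts for this pattern.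

On these data alone, it remains open whether the advantage of compound 2 belongs to its substitution place or to the methyl group itself, a question that 3-fluorophenyl and 4-methylphenyl on the same aromatic nitrogen would address. Also open, as far as these compounds go, is how an unsubstituted phenyl, a methoxy group or an amine on that ring would read in this assay against these four compounds.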